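Propylsulfanyl in place of sulfanyl on a second core

The source may report more compounds than this note shows. Statements on the series, on what has been measured and on what is new or still open speak of the compounds shown alone.

Measured compounds:
Compound 1, `O[C@@H]1[C@@H](O)[C@H](Oc2cccc3c(S)cccc23)OC[C@H]1O`, gives 110 uM in a functional assay on T-24 cells (Homo sapiens) for antiproliferative activity, read by crystal violet staining, with a stated time of 96 h; a higher number here means that more compound is needed for the effect, a lower number that less compound is needed.
Compound 2, `O[C@@H]1[C@@H](O)[C@H](Oc2cc3ccccc3cc2S)OC[C@H]1O`, gives 145 uM in this assay.
Compound 3, `CCCSc1cccc2c(O[C@@H]3OC[C@@H](O)[C@H](O)[C@H]3O)cccc12`, gives 40 uM in this assay.

Compounds 1 and 3 share one core, and compound 3 differs from compound 1 by a single change, (propyl in place of hydrogen on a sulfur). This change brought a 2.8-fold lower number from compound 1 to compound 3 (0.44 log units; beyond the scatter) in this assay, a modest step that lies beyond the scatter of repeated measurements.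

Compound 2 is built on a different core from compound 1; the two hold the same atoms joined differently, and the difference between the two cores is not broken down here. In this assay compound 2 stands within the scatter of compound 1, so no order between the two can be drawn, while compound 3 sits beyond the scatter from both.

Compound 4, `CCCSc1cc2ccccc2cc1O[C@@H]1OC[C@@H](O)[C@H](O)[C@H]1O`, is not yet measured. It differs from compound 2 by propyl in place of hydrogen on a sulfur, and the place of the change, a sulfur whose other neighbour is an aromatic carbon, reads the same as in the change from compound 1 to compound 3. So the change is the same change, carried onto the core of compound 2.

Within the data shown here, only one example of this change is measured, so the expectation rests on that single step. Because compound 3 showed a 2.8-fold lower number from compound 1 to compound 3 (0.44 log units; beyond the scatter), a step of about the same size, a 2.8-fold lower number from compound 2 to compound 4 (0.45 log units; beyond the scatter), is expected in this assay for compound 4. Compound 4 is therefore estimated at 52 uM, with a likely range from 25 uM to 110 uM.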

Compound 4, concentration for half-maximal effect: 70 uM
For compound 4 the middle estimate is 1.3-fold (0.13 log units) below the measured one, within the range that was stated.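

On the core of compound 2, propyl in place of hydrogen on the sulfur gave a 2.1-fold lower number from compound 2 to compound 4 (0.32 log units; beyond the scatter) in this assay, so the step runs in the same direction as on the core of compound 1 and again lies beyond the scatter. Set side by side, the two steps cannot be told apart in size: the same change on two cores in this assay, a 2.8-fold lower number (0.44 log units; beyond the scatter) from compound 1 to compound 3 and a 2.1-fold lower number (0.32 log units; beyond the scatter) from compound 2 to compound 4, 1.3-fold (0.12 log units) apart, within the scatter of two such steps. Across these two cores, then, the change from sulfanyl to propylsulfanyl carried over with its direction kept, but two pairs are a small sample, and they show neither why the number falls nor whether the same step would appear on any other core.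

The compounds shown carry only hydrogen or propyl on the sulfur, so it stays open how the number would respond to a shorter chain such as methyl, a longer chain such as hexyl, or a chain ending in an amine or a carboxylic acid. From the compounds shown here alone, it also stays open whether a step of this kind would be seen in any measurement other than this assay.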